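A few compounds are considered here, and "the series" means these few. Any claim that something is new, unique, unknown or untested is made for them only; others in the source may bear on it.

For the measured compounds named here, in a functional assay on A549 cells (Homo sapiens) for cytotoxicity, read by MTT assay, with a stated time of 72 h (on this read-out lower numbers stand for an effect already at smaller amounts and higher numbers for an effect only at larger amounts of compound), compound 1 `O=c1cc(NC2CCCCC2)cc(/C=C/c2ccccc2)o1` gives 1.25 uM, and compound 2 `COc1ccc(Nc2cc(/C=C/c3ccccc3)oc(=O)c2)cc1` gives 0.11 uM, the lower of the only two numbers so far. Compound 3 `COc1ccc(Nc2cc(C(C)C)oc(=O)c2)cc1` keeps the 4-methoxyphenyl of compound 2 but has isopropyl in place of 2-phenylethenyl on an aromatic carbon, next to the ring oxygen: isopropyl in place of 2-phenylethenyl on an aromatic carbon. Going by the values given here, no measured step touches this place, so the evidence is indirect. Among the compounds with values here, the one step available, an 11-fold lower number from compound 1 to compound 2 (1.06 log units; beyond the scatter), is large and shows that exchanging a single group on the shared core can shift the number substantially. A shift of similar size is therefore expected in this assay, towards a higher number, although that direction is a judgement without a measured precedent. In numbers, the expectation is a 14-fold higher number from compound 2 to compound 3 (1.13 log units; beyond the scatter). Compound 3 is estimated at 1.5 uM, with an expected range from 0.3 uM to 10 uM.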

Compound 3, concentration for half-maximal effect: > 30 uM
Compound 3 was reported as a limit; the forecaster's own chance of this, stated with the estimate: 10%; at least 20-fold (1.30 log units) between middle value and limit.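

In this assay, for the compounds shown here, this is the first measured change at the aromatic carbon next to the ring oxygen, and it gives an at least 270-fold higher number from compound 2 to compound 3 (2.43 log units; beyond the scatter), a far larger step than the one at the nitrogen, an 11-fold lower number from compound 1 to compound 2 (1.06 log units; beyond the scatter). The read-out therefore depends strongly on the group at this position, even with the 4-methoxyphenyl kept on the nitrogen. Compound 3 carries a limit rather than a number, so the full size of its step remains unknown: the limit of > 30 uM in this assay, at which 1 of the 3 values shown sits.

The change removes both a six-membered aromatic ring and a double bond outside aromatic rings, so these compounds cannot show which of the two matters, or whether the smaller size of isopropyl does. A 2-phenylethyl group, which keeps the ring without the double bond, or a plain phenyl on this carbon, would pull these possibilities apart.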